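This account rests on a few compounds, and the source may have more. Where it says the series, first, only, none or still open, it means among the compounds named here.

Measured compounds in the series:

- compound 1, `COCCNC(=O)c1ccc(-c2c(N)c(C(=O)c3ccc(F)cc3F)cc[n+]2[O-])c(C)c1`, 46 ug/mL
- compound 2, `Cc1cc(O)ccc1-c1c(N)c(C(=O)c2ccc(F)cc2F)cc[n+]1[O-]`, 37 ug/mL

For the measured compounds named here, compound 2 is the lower of the two numbers in a physicochemical assay for solubility, at pH 7.4 (on this read-out lower numbers stand for lower solubility and higher numbers for higher solubility), with compound 1 as its only neighbour; the gap between them is the step of a 1.2-fold lower number from compound 1 to compound 2 (0.09 log units; within the scatter), which is within the scatter and so does not separate the two compounds.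

Compound 3, `COCCOc1ccc(-c2c(N)c(C(=O)c3ccc(F)cc3F)cc[n+]2[O-])c(C)c1`, has not yet been measured in this assay. It differs from compound 2 by 2-methoxyethyl in place of hydrogen on an oxygen on an aromatic ring. Going by the values given here, the only measured step available is the one from compound 1 to compound 2, which exchanged the (2-methoxyethyl)carbamoyl group for hydroxy on the aromatic carbon and left the number within the scatter. Among the compounds with values here, no measured pair covers the capping of a hydroxy with a 2-methoxyethyl group, so the step to compound 3 is not directly informed. On the evidence of compound 1 and compound 2 sitting together, no step beyond the scatter is expected, and the estimated change is a 1.2-fold lower number from compound 2 to compound 3 (0.09 log units; within the scatter). For compound 3 the expected solubility in this assay is 30 ug/mL, with a range of 10 ug/mL to 90 ug/mL.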

Compound 3, solubility: 67 ug/mL
For compound 3 the middle estimate is 2.2-fold (0.35 log units) below the measured one, and the stated range covers the measured number.
By their numbers in this assay, from the lowest: compounds 2, 1 and 3 (each within the scatter of the next).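

In this assay, for the compounds shown here, capping the hydroxy on the aromatic ring with 2-methoxyethyl gives a 1.8-fold higher number from compound 2 to compound 3 (0.26 log units; within the scatter) and so does not separate the two compounds, which makes this the first measured step at this oxygen. Exchanging (2-methoxyethyl)carbamoyl for 2-methoxyethoxy on the aromatic carbon gives a 1.5-fold higher number from compound 1 to compound 3 (0.16 log units; within the scatter), so hydroxy, 2-methoxyethoxy and (2-methoxyethyl)carbamoyl at this place now all stand within the scatter of one another in this read-out, and none of the three can be ranked against the others. Nothing among the data shown offers an account of these numbers.

Still open, from the compounds shown here alone, is whether any group at this place moves the read-out beyond the scatter, for instance an amine, a carboxylic acid or a longer chain in place of 2-methoxyethyl on the oxygen. The three compounds also share the rest of their structure, so they leave unanswered whether the same closeness would hold on a different core or with other substituents elsewhere on this one.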